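Between Two Measured Ring Groups: Compound 4

The compounds below may be only part of what the source reports. "The series", "measured", "known", "first", "only" and "open" are said of these compounds alone.

Of the compounds shown here, three have been measured in an assay (strain Wistar) for inhibition of Fatty-acid amide hydrolase 1 (Rattus norvegicus), read by scintillation counting; a higher number here means a weaker inhibitor, a lower number a stronger inhibitor. Compound 1 `O=C(NC1CCCC1)Oc1cccc(C2=NCCO2)c1` gives 13 nM. Compound 2 `CC1(C)COC(c2cccc(OC(=O)NC3CCCC3)c2)=N1` gives 65 nM, the highest of the three numbers. Compound 3 `CC1(C)COC(c2cccc(OC(=O)NC3CCCCC3)c2)=N1` gives 46 nM. Two single-change steps connect them: a 5.0-fold higher number from compound 1 to compound 2 (0.70 log units; beyond the scatter), and a 1.4-fold lower number from compound 2 to compound 3 (0.15 log units; within the scatter). Compound 2 therefore stands close to compound 3 and furthest from compound 1.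

Compound 4 `C[C@H]1COC(c2cccc(OC(=O)NC3CCCC3)c2)=N1` has not yet been measured. It differs from compound 2 in one place: a group of 6 heavy atoms (4 carbon, 1 nitrogen, 1 oxygen; one five-membered non-aromatic ring with 2 hetero atoms) in place of a group of 7 heavy atoms (5 carbon, 1 nitrogen, 1 oxygen; one five-membered non-aromatic ring with 2 hetero atoms), on an aromatic carbon. The entering group is intermediate in size between the group of 5 heavy atoms found in compound 1 and the group of 7 heavy atoms found in compound 2.

Going by the values given here, only one measured step bears directly on this change, namely the enlargement of the ring group, where a 5.0-fold higher number from compound 1 to compound 2 (0.70 log units; beyond the scatter). Compound 4 carries a ring group of 6 heavy atoms, so part of that step is expected to reverse, while the remaining change on the amide-type nitrogen stays untouched. Compound 4 is therefore expected to give a lower number in this assay, a 2.2-fold lower number from compound 2 to compound 4 (0.34 log units; beyond the scatter). The estimate for compound 4 is 30 nM, with a range from 12 nM to 75 nM.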

Compound 4, half-maximal inhibitory concentration: 110 nM
Compound 4: the middle estimate sits 3.7-fold (0.56 log units) below what was measured, and the stated range ends below it.
By their numbers in this assay, from the lowest: compound 1; then compounds 3, 2 and 4 (each within the scatter of the next, the first and the last beyond it).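

In this assay, methyl in place of hydrogen on a saturated ring carbon of the five-membered ring gives an 8.5-fold higher number from compound 1 to compound 4 (0.93 log units; beyond the scatter), so this single added carbon is enough to separate the new compound clearly from the unsubstituted ring. The step of a 1.7-fold higher number from compound 2 to compound 4 (0.23 log units; within the scatter) means that taking one carbon out of the larger ring group leaves no difference that can be told from ordinary assay noise, so the number does not fall in line with the size of the group: among these three ring groups, only the unsubstituted ring stands apart, and the methyl-bearing and larger groups cannot be ranked against each other. Nothing available explains why one methyl has as large an effect as this.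

The compounds shown leave open whether the mirror-image form of the single-methyl ring group would give a similar number, since only one defined stereocentre appears here. They also leave open how an ethyl or a hydroxymethyl on that same ring carbon would compare, and whether cyclohexyl in place of cyclopentyl would matter with the single-methyl ring.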